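Aryl-fused piperidine series: methyl to chloro exchange

This account rests on a few compounds, and the source may have more. Where it says the series, first, only, none or still open, it means among the compounds named here.

Measured so far:
- compound 1 `Fc1ccc(-c2noc3c2CCNCC3)cc1`; in an assay on cells for displacement of a labelled ligand from 5-hydroxytryptamine receptor 4 (Homo sapiens), read by scintillation counting, with a stated time of 1.5 h (a lower number here means a stronger inhibitor, a higher number a weaker inhibitor), compound 1 gives > 10000 nM, which is a limit of the assay.
- compound 2 `Cc1ccc(-c2n[nH]c3c2CCNCC3)cc1`; in this assay compound 2 gives > 10000 nM, also a limit.
- compound 3 `Cc1ccc(-c2noc3c2CCNCC3)cc1`; in this assay compound 3 gives > 10000 nM, again a limit.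

Compound 3 thus stands at the edge of the assay together with the two others; the step that the two limits leave unreadable from compound 1 to compound 3 cannot be read, since both ends are limits (the limit of > 10000 nM in this assay, at which 3 of the 3 values shown sit). Compound 4 `Clc1ccc(-c2noc3c2CCNCC3)cc1` carries the change (chloro in place of methyl on an aromatic carbon). Going by the values given here, no measured step bears on this exchange, as every value shown is a limit. The expectation for compound 4 in this assay is therefore 15000 nM (range 3000 nM to 60000 nM), with an expected step that the limit leaves unreadable from compound 3 to compound 4 and most probably a further limit.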

Compound 4, inhibition constant: > 10000 nM
Compound 4: only a limit was reported; the forecaster's own chance of this, stated with the estimate: 80%; the middle value is on the limit's open side.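

No step can be read from compound 1 or compound 3 to compound 4, since both ends of each pair are limits: the limit of > 10000 nM in this assay, at which 4 of the 4 values shown sit.

The compounds shown leave open whether fluoro, methyl and chloro differ at all in this assay.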